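Swapping the phenyl group on two related cores

The source may hold more compounds than are shown below. What is called first, only, known or untested is meant among the compounds shown, and "the series" means these compounds.

Compound 1 `COc1cc(/C=C/C(=O)c2sc(Nc3cccc(Cl)c3)nc2C)cc(OC)c1OC` and compound 2 `COc1cc(/C=C/C(=O)c2sc(Nc3ccc(C)cc3)nc2C)cc(OC)c1OC` share a core and differ in one place: 4-methylphenyl in place of 3-chlorophenyl on a nitrogen on an aromatic ring. In a functional assay on Bel-7402 cells (Homo sapiens) for cytotoxicity, read by MTT assay (a higher number here means a weaker inhibitor, a lower number a stronger inhibitor), compound 1 gives 14000 nM. Compound 2 reaches only a limit of this assay, > 25000 nM. The change gave an at least 1.7-fold higher number from compound 1 to compound 2 (0.25 log units; that floor lies within the scatter), a floor that rests on (the limit of > 25000 nM in this assay, at which 2 of the 3 values shown sit). Compound 3 `COc1cccc(/C=C/C(=O)c2sc(Nc3cccc(Cl)c3)nc2C)c1` has a different core; the difference between the two cores is not broken down here. In this assay compound 3 also gives only a limit, > 25000 nM. Compound 4 `COc1cccc(/C=C/C(=O)c2sc(Nc3ccc(C)cc3)nc2C)c1` carries the same change on this core, (4-methylphenyl in place of 3-chlorophenyl on a nitrogen on an aromatic ring). With compound 3 at the limit and the same change having given an at least 1.7-fold higher number from compound 1 to compound 2 (0.25 log units; that floor lies within the scatter), compound 4 is expected to remain there, an expected step that the limit leaves unreadable from compound 3 to compound 4. The estimate for compound 4 is 30000 nM, likely between 15000 nM and 60000 nM.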

Compound 4, half-maximal inhibitory concentration: > 25000 nM
Compound 4 ended at the assay's limit (the forecaster's own chance of this, stated with the estimate: 85%); the middle value is on the limit's open side.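

Compound 3 and compound 4 both stop at a limit of this assay, so no step between them can be read: the limit of > 25000 nM in this assay, at which 3 of the 4 values shown sit.

The compounds shown leave open whether 4-methylphenyl in place of 3-chlorophenyl changes anything on the core of compound 3.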